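This account rests on a few compounds, and the source may have more. Where it says the series, first, only, none or still open, it means among the compounds named here.

Compound 1 `O=C(O)c1cnc(-c2ccccc2O)[nH]c1=O`: > 5 mg/kg
Compound 2 `CCOC(=O)c1cnc(-c2ccccc2O)[nH]c1=O`: 5 mg/kg

Both compounds were tested in a functional assay on the whole organism (strain Sprague-Dawley) for inhibition, with Rattus norvegicus as the target, with a stated time of 10 min; on this read-out higher numbers stand for an effect only at larger amounts of compound and lower numbers for an effect already at smaller amounts. For compound 1 the result is a limit of the assay, not a number: the limit of > 5 mg/kg in this assay, at which 1 of the 2 values shown sits. Within the data shown here, compound 2 therefore holds the only true number so far, 5 mg/kg. Its standing can only be judged against the result for compound 1.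

Compound 3 `CCCCOc1ccccc1-c1ncc(C(=O)OCC)c(=O)[nH]1` is compound 2 with one change: butyl in place of hydrogen on an oxygen on an aromatic ring. In other words, hydroxy becomes butoxy.

Among the measured compounds shown here, no measured step covers this exact place. The nearest guide is a number no higher from compound 1 to compound 2 (the limit leaves the size open). That step also replaces a hydrogen on an oxygen, but elsewhere in the molecule and with ethyl, and the number did not rise. From the compounds shown here alone, this single comparison is weak evidence, and its size remains open. It leads to a cautious expectation of a lower number, meaning an effect at a smaller dose, although a result near compound 2 would be no surprise. The expected change is a 2.5-fold lower number from compound 2 to compound 3 (0.40 log units; beyond the scatter). For compound 3 the estimated value is 2 mg/kg, with an expected range from 0.3 mg/kg to 10 mg/kg.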

Compound 3, dose for 50% inhibition: 0.5 mg/kg
Beside the measured number, compound 3's estimate is 4.0-fold (0.60 log units) above it; low and high end bracket the measured number.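

Replacing the hydrogen on the oxygen on the aromatic ring with butyl gives a 10-fold lower number from compound 2 to compound 3 (1.00 log units; beyond the scatter) in this assay, so the hydroxy group, with its free hydrogen, is not required for an effect in this assay. This is the first change among these compounds whose size can be read, and it shows that this position responds strongly to a change, with the butoxy compound acting at a smaller dose. The earlier step, at the oxygen next to a carbonyl group, could not show this, since compound 1 gave only a limit and not a number: the limit of > 5 mg/kg in this assay, at which 1 of the 3 values shown sits.

With a single chain at this position, the compounds shown cannot separate the effect of the butyl chain itself from the effect of removing the hydrogen from that oxygen, and they give no measured reason for the drop. A short methyl group or a longer hexyl chain on the same oxygen would show how the result depends on chain length, while the carboxylic acid of compound 1 leaves open whether butoxy has the same effect without the ethyl group.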